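The compounds below may be only part of what the source reports. "The series", "measured", "known", "first", "only" and "open" are said of these compounds alone.

Values so far in a functional assay on the whole organism with Rattus norvegicus as the target; a lower number here means that less compound is needed, a higher number that more compound is needed for the effect

Compound 1 `CCOCCOC(=O)C(=O)Nc1nc(-c2cc(Cl)no2)cs1` gives 6 mg/kg
Compound 2 `COCCOC(=O)C(=O)Nc1nc(-c2cc(Br)no2)cs1` gives 7 mg/kg

Compound 1 and compound 2 lie within the usual scatter of each other, so these numbers cannot separate them. Compound 3 `CCOCCOC(=O)C(=O)Nc1nc(-c2cc(OC)no2)cs1` keeps the rest of compound 1 but has methoxy in place of chloro on an aromatic carbon. Among the measured compounds shown here, no two measured compounds differ in just one place, so no measured step can guide this estimate. A modest move toward a higher number is expected, with a 1.7-fold higher number from compound 1 to compound 3 (0.22 log units; within the scatter) as the estimated step. In this assay the estimate for compound 3 is 10 mg/kg within an expected range of 3 mg/kg to 30 mg/kg overall.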

Compound 3, dose for half-maximal effect: 3 mg/kg
Compound 3: middle estimate off by 3.3-fold (0.52 log units), on the high side; the measured number falls inside the stated range.
By their numbers in this assay, from the lowest: compounds 3, 1 and 2 (each within the scatter of the next, the first and the last beyond it).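

Among the compounds shown here, the first readable step in this assay is the change from 3-chloro-1,2-oxazol-5-yl to 3-methoxy-1,2-oxazol-5-yl, with a 2.0-fold lower number from compound 1 to compound 3 (0.30 log units; within the scatter). So this position can carry methoxy, which brings a hydrogen-bond acceptor that chloro lacks, and the number does not move beyond the usual scatter. No measurement here offers an explanation for this result. As far as these compounds go, whether an amine, a hydroxyl or a longer chain such as ethoxy at this position would give a step beyond the scatter remains open.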